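Removing both chlorines from compound 3

The source may report more compounds than this note shows. Statements on the series, on what has been measured and on what is new or still open speak of the compounds shown alone.

Among the three measured compounds, compound 3 `CCN(CC)Cc1ccc2nc(NC(=O)N/N=C/c3cn(Cc4ccc(Cl)cc4Cl)c4ccccc34)sc2c1` gives the highest number in a functional assay on MDA-MB-231 cells (Homo sapiens) for cytotoxicity, read by MTT assay, with a stated time of 72 h (on this read-out lower numbers stand for stronger inhibition and higher numbers for weaker inhibition), at 3280 nM. Compound 1 `CCN(CC)Cc1ccc2nc(NC(=O)N/N=C/c3cn(Cc4ccccc4Cl)c4ccccc34)sc2c1` gives 900 nM and compound 2 `CN(C)Cc1ccc2nc(NC(=O)N/N=C/c3cn(Cc4ccccc4)c4ccccc34)sc2c1` gives 1340 nM. Compound 4 `CCN(CC)Cc1ccc2nc(NC(=O)N/N=C/c3cn(Cc4ccccc4)c4ccccc34)sc2c1` differs from compound 3 by phenyl in place of 2,4-dichlorophenyl on a saturated chain carbon bound to an aromatic nitrogen. Among the compounds with values here, the one step that bears on it is a 3.6-fold higher number from compound 1 to compound 3 (0.56 log units; beyond the scatter), which went the other way, adding one chloro. Compound 4 strips away that chloro and the second one too, and compound 2, which also carries a plain benzyl, sits close to compound 1. A modest drop in the number is therefore expected, a 3.3-fold lower number from compound 3 to compound 4 (0.52 log units; beyond the scatter). Compound 4 is estimated at 1000 nM, within a range from 500 nM to 2100 nM.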

Compound 4, half-maximal inhibitory concentration: 1470 nM
The estimate for compound 4 lay 1.5-fold (0.17 log units) below the measured number, and the stated range covers the measured number.
By their numbers in this assay, from the lowest: compounds 1, 2 and 4 (each within the scatter of the next); then compound 3.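

In this assay the change from 2,4-dichlorophenyl to phenyl gives a 2.2-fold lower number from compound 3 to compound 4 (0.35 log units; beyond the scatter) and stays beyond the scatter, whereas a 1.6-fold higher number from compound 1 to compound 4 (0.21 log units; within the scatter) lies within it, so among these compounds only the 2,4-dichlorobenzyl group stands apart, and the single chloro of compound 1 does not. With the plain benzyl in place, diethylamino and dimethylamino cannot be told apart, at a 1.1-fold higher number from compound 2 to compound 4 (0.04 log units; within the scatter). Nothing shown explains the difference between these benzyl groups. Going by these compounds, what a methoxy or a nitrile on the phenyl would do remains open, and so does a morpholine in place of diethylamino.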